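Trifluoromethyl for trifluoromethoxy on the sulfonyl aryl ring

The source may hold more compounds than are shown below. What is called first, only, known or untested is meant among the compounds shown, and "the series" means these compounds.

Among the compounds with values here, compound 3 `CCN(CC)c1ccc2cc(C(=O)c3ccc(N4CCN(C(=O)CN5CCN(S(=O)(=O)c6ccc(OC(F)(F)F)cc6)CC5)CC4)cc3)oc2c1` holds the only number in an ADME assay on L02 cells (Homo sapiens) for cytotoxicity, read by MTT assay, with a stated time of 48 h; a higher number here means a weaker inhibitor, a lower number a stronger inhibitor: compound 3 gives 34700 nM. Compound 1 `CCN(CC)c1ccc2cc(C(=O)c3ccc(N4CCN(C(=O)CN5CCN(C(=O)/C=C/c6ccccc6)CC5)CC4)cc3)oc2c1` sits at the limit > 100000 nM in this assay. Compound 2 `CCN(CC)c1ccc2cc(C(=O)c3ccc(N4CCN(C(=O)CN5CCN(S(=O)(=O)C6CC6)CC5)CC4)cc3)oc2c1` likewise sits at the limit > 100000 nM. This is the limit of > 100000 nM in this assay, at which 2 of the 3 values shown sit. The step that the two limits leave unreadable from compound 1 to compound 2 is thus unreadable, whereas an at least 2.8-fold lower number from compound 2 to compound 3 (0.45 log units; beyond the scatter). Compound 4 `CCN(CC)c1ccc2cc(C(=O)c3ccc(N4CCN(C(=O)CN5CCN(S(=O)(=O)c6ccc(C(F)(F)F)cc6)CC5)CC4)cc3)oc2c1` differs from compound 3 by trifluoromethyl in place of trifluoromethoxy on an aromatic carbon. Within the data shown here, no measured step alters a substituent on an aryl sulfonyl ring; the readable step from compound 2 to compound 3 exchanges the whole group on the sulfonyl sulfur, so it bears only loosely here. A step within the scatter is expected, a 1.0-fold higher number from compound 3 to compound 4 (0.00 log units; within the scatter). Compound 4 is estimated at 35000 nM, with a range from 12000 nM to 100000 nM.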

Compound 4, half-maximal inhibitory concentration: 17000 nM
Compound 4: middle estimate off by 2.1-fold (0.31 log units), on the high side; measured number inside the range.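

In this assay, the substituent on the aryl ring of the sulfonyl group matters on its own, with a 2.0-fold lower number from compound 3 to compound 4 (0.31 log units; beyond the scatter). Exchanging cyclopropyl on the sulfonyl sulfur for a second aryl group also gives an at least 5.8-fold lower number from compound 2 to compound 4 (0.76 log units; beyond the scatter), so both aryl sulfonyl compounds shown lie on the same side of compound 2. The value of compound 2 is a limit and not a number, so this step has no upper size: the limit of > 100000 nM in this assay, at which 2 of the 4 values shown sit.

Still open, on these data alone, is how a nitrile, an amine or a carboxylic acid at this place on the ring would read.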